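Swapping the neighbouring group on the shared core

A few compounds are considered here, and "the series" means these few. Any claim that something is new, unique, unknown or untested is made for them only; others in the source may bear on it.

Measured compounds:
- compound 1, `CC(C(=O)NCc1ccc(C(C)(C)C)nc1N1CCCCCC1)c1ccc(NS(C)(=O)=O)c(F)c1`: 0.9 nM
- compound 2, `CC(C(=O)NCc1ccc(C(C)(C)C)nc1OC1CCCCC1)c1ccc(NS(C)(=O)=O)c(F)c1`: 2.5 nM
- compound 3, `COc1ccc(CSc2nc(C(C)(C)C)ccc2CNC(=O)C(C)c2ccc(NS(C)(=O)=O)c(F)c2)cc1`: 3.5 nM

These three share a core and differ only in one group on an aromatic carbon of the ring that carries the tert-butyl group. In an assay on cells for antagonist activity at transient receptor potential cation channel subfamily V member 1 (Homo sapiens), read by FLIPR and calcium flux, with a stated time of 6 min (on this read-out higher numbers stand for weaker inhibition and lower numbers for stronger inhibition), compound 1 gives 0.9 nM, compound 2 gives 2.5 nM and compound 3 gives 3.5 nM. Compound 3 thus has the highest number of the three; the two steps leading up to it are a 1.4-fold higher number from compound 2 to compound 3 (0.15 log units; within the scatter) and a 3.9-fold higher number from compound 1 to compound 3 (0.59 log units; beyond the scatter).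

Compound 4, `CC(C(=O)NCc1ccc(C(C)(C)C)nc1C1CCCCC1)c1ccc(NS(C)(=O)=O)c(F)c1`, has not been measured. It differs from compound 3 by cyclohexyl in place of (4-methoxybenzyl)sulfanyl on an aromatic carbon. The entering cyclohexyl resembles the groups in compound 1 and compound 2 in being a ring of similar size without a hydrogen-bond acceptor in the linker. The steps seen so far are a 2.8-fold higher number from compound 1 to compound 2 (0.44 log units; beyond the scatter) and a 3.9-fold higher number from compound 1 to compound 3 (0.59 log units; beyond the scatter), both modest, and the difference between compound 2 and compound 3 is within scatter. A step of similar modest size, toward a lower number, is therefore expected from compound 3 to compound 4: a 2.3-fold lower number from compound 3 to compound 4 (0.37 log units; beyond the scatter). Compound 4 is estimated at 1.5 nM in this assay, with a likely range from 0.5 nM to 5 nM.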

Compound 4, inhibition constant: 3.1 nM
Beside the measured number, compound 4's estimate is 2.1-fold (0.32 log units) below it, within the range that was stated.
By their numbers in this assay, from the lowest: compound 1; then compounds 2, 4 and 3 (each within the scatter of the next).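

In this assay, cyclohexyl in place of (4-methoxybenzyl)sulfanyl gives a 1.1-fold lower number from compound 3 to compound 4 (0.05 log units; within the scatter) and cyclohexyl in place of cyclohexyloxy gives a 1.2-fold higher number from compound 2 to compound 4 (0.09 log units; within the scatter), so compounds 2, 3 and 4 cannot be told apart on this read-out. This position therefore tolerates the change from 10 heavy atoms to 6 heavy atoms, and from an aromatic ring with 2 hydrogen-bond acceptors to a non-aromatic ring with none, without a change beyond the scatter; the earlier compounds had not shown that a group with no oxygen or sulfur linking it to the ring could match those two. Only azepan-1-yl stands apart, with a 3.4-fold higher number from compound 1 to compound 4 (0.54 log units; beyond the scatter) and the lowest number of the four, but no measurement at hand explains this.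

The compounds shown leave open whether that advantage of compound 1 goes with its seven-membered ring or with its attachment through nitrogen. Cycloheptyl and piperidin-1-yl at this position would pull those two features apart, while a dimethylamino group would show whether any ring is needed at all.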